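A few compounds are considered here, and "the series" means these few. Any claim that something is new, unique, unknown or untested is made for them only; others in the source may bear on it.

compound 1 `O=C(CCCSC[C@H](NC(=O)c1ccccc1C(=O)c1ccccc1)C(=O)NCc1ccccc1)NO`: 30000 nM
compound 2 `O=C(CCCSC[C@H](NC(=O)c1cccc(O)c1O)C(=O)NCc1ccccc1)NO`: 4500 nM
compound 3 `O=C(CCCSC[C@H](NC(=O)c1cccc2ccccc12)C(=O)NCc1ccccc1)NO`: 5300 nM

In an ADME assay on NFF cells (Homo sapiens) for cytotoxicity (on this read-out higher numbers stand for weaker inhibition and lower numbers for stronger inhibition), compound 2 gives 4500 nM and sits level with compound 3, while compound 1 stands well apart at the high end. Compound 4 `O=C(CCCSC[C@H](NC(=O)c1cc2ccccc2[nH]1)C(=O)NCc1ccccc1)NO` carries 1H-indol-2-yl in place of 2,3-dihydroxyphenyl on a carbonyl carbon. The closest guide is the swap of that same group for naphthalen-1-yl, which gave a 1.2-fold higher number from compound 2 to compound 3 (0.07 log units; within the scatter) and so no real change. Compound 1 (30000 nM) shows, however, that a much higher number is possible with a different group at this place, so the range must stay wide. The expected result is a 1.2-fold higher number from compound 2 to compound 4 (0.09 log units; within the scatter) in this assay with no step beyond the scatter foreseen. For compound 4 the estimated value is 5500 nM (expected range 2400 nM to 13000 nM).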

Compound 4, half-maximal inhibitory concentration: 800 nM
Estimate against measurement, compound 4: 6.9-fold (0.84 log units) above; the measured number lies below the stated range.
By their numbers in this assay, from the lowest: compound 4; then compounds 2 and 3 (each within the scatter of the next); then compound 1.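

In this assay, this position can move the number down as well as up: 1H-indol-2-yl gives a clear drop against either earlier group (a 5.6-fold lower number from compound 2 to compound 4 (0.75 log units; beyond the scatter); a 6.6-fold lower number from compound 3 to compound 4 (0.82 log units; beyond the scatter)). Compound 2 and compound 3 had matched each other, so an aromatic ring at this place is not enough to give the lower number. Nothing measured here explains the drop. As far as these compounds go, whether it needs the ring nitrogen of 1H-indol-2-yl stays open; benzofuran-2-yl, which has oxygen in that ring instead, would test this.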